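Iodo entering compound 2: working notes on the series

This account rests on a few compounds, and the source may have more. Where it says the series, first, only, none or still open, it means among the compounds named here.

Measured so far:
- compound 1 `CO/N=c1/ccn([C@]23C[C@H]2[C@H](COP(=O)(O)OP(=O)(O)OP(=O)(O)OC[C@@H]2[C@@H](O)[C@@H](O)[C@@]4(n5ccc(=O)[nH]c5=O)C[C@@H]24)[C@@H](O)[C@H]3O)c(=O)[nH]1` gives 6900 nM in a functional assay on cells for agonist activity at P2Y purinoceptor 6 (Homo sapiens), read by FLIPR and calcium flux; a lower number here means that less compound is needed, a higher number that more compound is needed for the effect
- compound 2 `O=c1ccn([C@]23C[C@H]2[C@H](COP(=O)(O)OP(=O)(O)O)[C@@H](O)[C@H]3O)c(=O)[nH]1` gives 438 nM in this assay

Compound 2 holds the lowest of the two numbers in this assay. Within the data shown here, compound 1 is the only other measured member, and its number is higher than that of compound 2 by an amount beyond the usual scatter; the two compounds differ in more than one place, so only their two values can be compared, and no single change is assigned to that gap.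

Compound 3 `O=c1[nH]c(=O)n([C@]23C[C@H]2[C@H](COP(=O)(O)OP(=O)(O)O)[C@@H](O)[C@H]3O)cc1I` has not yet been measured in this assay. It differs from compound 2 by iodo in place of hydrogen on an aromatic carbon. Among the measured compounds shown here, no pair of measured compounds shows this change, so the expectation rests on compound 2 alone and on the size of the group that enters.

The step from compound 2 to compound 3 is expected to be a lowering of the number in this assay, of moderate size, not large, a 2.9-fold lower number from compound 2 to compound 3 (0.47 log units; beyond the scatter). For compound 3 the estimated value in this assay is 150 nM, with a range from 40 nM to 600 nM.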

Compound 3, half-maximal effective concentration: 440 nM
Beside the measured number, compound 3's estimate is 2.9-fold (0.47 log units) below it, and the stated range covers the measured number.
By their numbers in this assay, from the lowest: compounds 2 and 3 (each within the scatter of the next); then compound 1.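

The single-place step in this assay is a 1.0-fold higher number from compound 2 to compound 3 (0.00 log units; within the scatter), within the scatter, so iodo in place of hydrogen on this aromatic carbon, two atoms from the ring nitrogen, gives no readable change in the number. Among these compounds, this is the first direct reading of any one position, and it shows that this carbon can carry iodo while compound 2 and compound 3 remain level in the functional read-out. The available data offer no measurement that bears on why the step is flat.

On these data alone, one step speaks for iodo alone, so it remains open whether a smaller atom such as fluorine, a methyl group, an amine, a carboxylic acid or a longer chain on the same carbon would also leave the number level or would move it beyond the scatter. As far as these compounds go, it also remains open whether iodo on this carbon would read the same on the core of compound 1, where the other parts of the structure differ from those of compound 2 in more than one place.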